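Removing a Methyl from a Weak Triazole Cytotoxin

This account rests on a few compounds, and the source may have more. Where it says the series, first, only, none or still open, it means among the compounds named here.

Compound 1 `COc1ccc(-c2cn(-c3ccc(Oc4ccccc4)cc3)nn2)cc1OC`: 10000 nM
Compound 2 `COc1ccc(-c2cn(-c3ccc(OC)c(OC)c3)nn2)cc1O`: > 100 nM
Compound 3 `COc1ccc(-c2cn(-c3ccc(OC)c(OC)c3)nn2)cc1OC`: "not determined" (no result reported)

Of the compounds shown here, three sharing one core have been tested in a functional assay on MDA-MB-231 cells (Homo sapiens) for cytotoxicity, read by MTT assay; on this read-out lower numbers stand for stronger inhibition and higher numbers for weaker inhibition. Going by the values given here, compound 1 gives 10000 nM, the only full number in the set, so it stands alone as the reference point. Compound 2 gives > 100 nM, which is a limit of the assay and not a number. For compound 3 the entry reads "not determined" (no result reported), so no result was reported. Among the compounds with values here, the set therefore offers one number, one limit and one blank, and no step between two measured compounds can be drawn from it.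

Compound 4 `COc1ccc(-c2cn(-c3ccc(Oc4ccccc4)cc3)nn2)cc1O` has not been measured. It differs from compound 1 by hydrogen in place of methyl on an oxygen on an aromatic ring; cut one bond further out, methoxy becomes hydroxy. Within the data shown here, the only guide is the single number of compound 1, and nothing in the measured data shows how this change moves potency. The step from compound 1 to compound 4 is expected to be no change at the digits printed from compound 1 to compound 4 (within the scatter), no larger than the usual scatter in either direction. Compound 4 is estimated at 10000 nM, with a likely range from 3000 nM to 30000 nM.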

Compound 4, half-maximal inhibitory concentration: > 10000 nM
Compound 4 was reported as a limit; the forecaster's own chance of this, stated with the estimate: 25%; the middle value sits exactly at the limit.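

In this assay, compound 4 is reported as > 10000 nM, which is a limit of the assay and not a number. The change from methoxy to hydroxy, with hydrogen in place of methyl on an oxygen on an aromatic ring, gives a number no lower from compound 1 to compound 4 (the limit leaves the size open), so this first look at the position shows no gain in potency, while any loss cannot be sized. The entry for compound 4 therefore gives a direction that is bounded on one side only, and it stops at a limit of the assay: the limit of > 10000 nM in this assay, at which 1 of the 4 values shown sits.

The compounds shown leave open whether a different group on this oxygen, such as an ethyl chain or a short chain ending in an amine or a carboxylic acid, would bring the number down. Going by these compounds alone, compound 2 and compound 3 differ by the same change with a different group elsewhere in the molecule, but a limit and a blank entry give no step that can be read, so it also stays open whether the change behaves the same way there.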